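The source may hold more compounds than are shown below. What is called first, only, known or untested is meant among the compounds shown, and "the series" means these compounds.

Measured compounds:
Compound 1 `COc1nn(Cc2cccc([N+](=O)[O-])c2)c(=O)o1` gives 7% in an assay on COS-7 cells for inhibition of Fatty-acid amide hydrolase 1 (Homo sapiens), read by scintillation counting, with a stated time of 10 min, tested at 10 uM; on this read-out lower numbers stand for less inhibition and higher numbers for more inhibition at the one concentration tested (going by the name of the read-out).
Compound 2 `CCOc1nn(Cc2cccc([N+](=O)[O-])c2)c(=O)o1` is reported as "not active" (no number reported) in this assay, with no number given.

Both measured compounds share a common core and differ only in the small alkoxy group on that core. Compound 1 sits low on the read-out in this assay, and compound 2 carries no number at all, only the report that it is not active; on the numbers shown it therefore stands at the bottom, with nothing to separate it from the low value of compound 1.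

Compound 3 `CCOc1nn(Cc2cccc(N)c2)c(=O)o1` is not yet measured. It is derived from compound 2 by a single change, (amino in place of nitro on an aromatic carbon). For the measured compounds named here, both measured compounds keep the nitro group, so no measured pair shows what this exchange does. Given that compound 2 is reported as "not active" (no number reported) and compound 1 gives only 7%, the expectation for this step in this assay is no movement beyond the usual scatter, in either direction. Compound 3 is accordingly estimated at 5% in this assay, within a range of -10% to 20%.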

Compound 3, a percentage reported as inhibition, at one concentration (the size of the read-out at that concentration, not a potency): 10%
Compound 3: the middle estimate sits 5 percentage points below what was measured, within the range that was stated.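

In this assay, for the compounds shown here, compound 3 gives 10% but compound 2 has no number, so no step between these two compounds can be read. The compounds shown leave open what amino in place of nitro does to inhibition in this series. No supporting evidence bears on this result.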